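A few compounds are considered here, and "the series" means these few. Any claim that something is new, unique, unknown or untested is made for them only; others in the source may bear on it.

Going by the values given here, compound 1 `Cn1cc(-c2cc(C(C)(C)O)ccc2OC2CC2)c2cc(C(=O)NCCCCCCC(=O)NO)[nH]c2c1=O` is one of three compounds measured in a functional assay on MV4-11 cells (Homo sapiens) for antiproliferative activity, read by CCK-8 assay, with a stated time of 72 h; a higher number here means a weaker inhibitor, a lower number a stronger inhibitor. In this assay compound 1 gives 220 nM, the second highest of the three numbers. Compound 2 `Cn1cc(-c2cc(C(C)(C)O)ccc2OC2CC2)c2cc(C(=O)NCc3ccc(C(=O)NO)cc3)[nH]c2c1=O` gives 420 nM in this assay, and compound 3 `Cn1cc(-c2ccccc2Oc2ccccc2)c2cc(C(=O)NCCCCCCC(=O)Nc3ccccc3N)[nH]c2c1=O` gives 130 nM. Among the compounds with values here, compound 3 differs from compound 1 at more than one place, so no single step connects them, and only the two values themselves can be set side by side; they lie close together. Within the data shown here, the only measured step that changes one place, a 1.9-fold higher number from compound 1 to compound 2 (0.28 log units; within the scatter), concerns the hydroxamic acid end of the molecule rather than the oxygen on the aromatic ring.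

Compound 4 `Cn1cc(-c2cc(C(C)(C)O)ccc2Oc2ccc(F)cc2F)c2cc(C(=O)NCCCCCCC(=O)NO)[nH]c2c1=O` has not yet been measured in this assay. It differs from compound 1 in one place: 2,4-difluorophenyl in place of cyclopropyl on an oxygen on an aromatic ring. Among the measured compounds shown here, no measured step changes this group alone, so the change rests on indirect support. Compound 3, whose value 130 nM sits near that of compound 1, is the nearest comparison, though it differs at more than one place. The step expected for compound 4 is therefore a 1.2-fold lower number from compound 1 to compound 4 (0.09 log units; within the scatter), which would not reach beyond the scatter. Compound 4 is estimated at 180 nM, within a range from 70 nM to 450 nM.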

Compound 4, half-maximal inhibitory concentration: 250 nM
Compound 4: middle estimate off by 1.4-fold (0.14 log units), on the low side; the range from low to high includes it.
By their numbers in this assay, from the lowest: compounds 3, 1, 4 and 2 (each within the scatter of the next, the first and the last beyond it).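

In this assay the swap of cyclopropyl, with 3 heavy atoms, for 2,4-difluorophenyl, with 8 heavy atoms and an aromatic ring, on the oxygen on an aromatic ring gives a 1.1-fold higher number from compound 1 to compound 4 (0.06 log units; within the scatter) and leaves the two compounds indistinguishable. For this one pair, then, the position takes a much larger ring carrying two fluorines without any difference that can be told from the scatter, which the earlier step, made at the hydroxamic acid end, could not show. Nothing at hand explains why the two compounds read alike.

As far as these compounds go, it remains open whether this tolerance extends to other kinds of group on the same oxygen, such as a chain ending in an amine or a carboxylic acid, or a longer chain such as n-hexyl. The compounds shown also leave open whether 2,4-difluorophenyl would read the same when paired with the 4-(hydroxycarbamoyl)phenyl end of compound 2, and what each of the two fluorines contributes on its own.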